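The source may hold more compounds than are shown below. What is called first, only, known or untested is meant among the compounds shown, and "the series" means these compounds.

Measured so far:
compound 1 `CN1CCN(c2ccc(C3=NN(C(=O)c4ccc(C(F)(F)F)cc4)C(c4ccc(N(C)C)cc4)C3)cc2)CC1` — 55.4%
compound 2 `CN1CCN(c2ccc(C3=NN(S(C)(=O)=O)C(c4ccc(N(C)C)cc4)C3)cc2)CC1` — 0.6%
compound 3 `CN(C)c1ccc(C2CC(c3ccc(-n4ccnc4)cc3)=NN2C(=O)c2ccc(C(F)(F)F)cc2)cc1` — 17.9%

In a functional assay on MDA-MB-231 cells (Homo sapiens) for inhibition, read by sulforhodamine B assay, tested at 10 uM (on this read-out higher numbers stand for more inhibition at the one concentration tested (going by the name of the read-out) and lower numbers for less inhibition), compound 1 gives 55.4%. Compound 2 gives 0.6%. Compound 3 gives 17.9%.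

Two pairs carry the same kind of change. From compound 1 to compound 2 the change is methylsulfonyl in place of (4-(trifluoromethyl)phenyl)carbonyl on an amine nitrogen in a ring and the step is a number 54.8 percentage points lower from compound 1 to compound 2 (beyond the scatter). Compound 4 `CN(C)c1ccc(C2CC(c3ccc(-n4ccnc4)cc3)=NN2S(C)(=O)=O)cc1` arises from compound 3 by methylsulfonyl in place of (4-(trifluoromethyl)phenyl)carbonyl on an amine nitrogen in a ring. The two cores differ by 1H-imidazol-1-yl in place of 4-methylpiperazin-1-yl on an aromatic carbon, with the step of a number 37.5 percentage points lower from compound 1 to compound 3 (beyond the scatter). The places are not the same word for word: in the first pair the ring atom two ring bonds away bears a large group, in the second a 4-(1H-imidazol-1-yl)phenyl group, so this counts as the same kind of change, not the same.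

For compound 4 in this assay a step of a number 15.9 percentage points lower from compound 3 to compound 4 (beyond the scatter) is expected, resting on the step of a number 54.8 percentage points lower from compound 1 to compound 2 (beyond the scatter) and on compound 3 starting from 17.9%. Compound 4 is estimated at 2%, expected between 0% and 12%.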

Compound 4, a percentage reported as inhibition, at one concentration (the size of the read-out at that concentration, not a potency): 12%
Beside the measured number, compound 4's estimate is 10 percentage points below it; low and high end bracket the measured number.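

With the nitrogen group changed, the step is a number 5.9 percentage points lower from compound 3 to compound 4 (within the scatter), and with the aromatic group changed on the methylsulfonyl core it is a number 11.4 percentage points higher from compound 2 to compound 4 (beyond the scatter). In this assay, the change to methylsulfonyl does not carry over at the same size from one core to the other: the same change on two cores in this assay, a number 54.8 percentage points lower (beyond the scatter) from compound 1 to compound 2 and a number 5.9 percentage points lower (within the scatter) from compound 3 to compound 4, 48.9 percentage points apart, beyond the scatter of two such steps

The change to 1H-imidazol-1-yl even runs in opposite directions on the two cores, but these compounds form a single set of two paired changes, so both gaps are one finding and give no rule for other cores: the same change on two cores in this assay, a number 37.5 percentage points lower (beyond the scatter) from compound 1 to compound 3 and a number 11.4 percentage points higher (beyond the scatter) from compound 2 to compound 4, 48.9 percentage points apart, beyond the scatter of two such steps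

Still open, from the compounds shown here alone, is how other groups on the ring nitrogen, such as acetyl or unsubstituted benzoyl, would behave. Also open, going by these compounds, is whether a morpholin-4-yl group on the aromatic carbon would follow compound 1 or compound 3.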